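Allyl to 4-methoxyphenyl on the thiourea nitrogen

The source may report more compounds than this note shows. Statements on the series, on what has been measured and on what is new or still open speak of the compounds shown alone.

Compound 1 `C=CCNC(=S)N/N=C\c1ccnc2ccccc12` is the allyl thiosemicarbazone of the shared core. In an ADME assay on RAW264.7 cells (Mus musculus) for cytotoxicity, read by MTT assay, with a stated time of 48 h (on this read-out higher numbers stand for lower toxicity in this test and lower numbers for higher toxicity in this test), compound 1 gives 105000 nM, the second highest of three numbers; compound 3 `S=C(N/N=C\c1ccnc2ccccc12)Nc1ccccc1` gives 118000 nM and compound 2 `S=C(N/N=C\c1ccnc2ccccc12)Nc1ccc(Br)cc1` gives 53500 nM. The steps already seen on this nitrogen are a 1.1-fold higher number from compound 1 to compound 3 (0.05 log units; within the scatter) and a 2.0-fold lower number from compound 1 to compound 2 (0.29 log units; within the scatter); on the aryl ring itself, a 2.2-fold higher number from compound 2 to compound 3 (0.34 log units; beyond the scatter). Compound 4 `COc1ccc(NC(=S)N/N=C\c2ccnc3ccccc23)cc1` carries the change (4-methoxyphenyl in place of allyl on an amide-type nitrogen). Both aryl replacements at this nitrogen stayed near compound 1, so for compound 4 a step of a 1.2-fold lower number from compound 1 to compound 4 (0.07 log units; within the scatter) is expected, nothing clearly beyond the scatter. Compound 4 is therefore estimated at 90000 nM, within 40000 nM to 200000 nM.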

Compound 4, half-maximal cytotoxic concentration: 101000 nM
The estimate for compound 4 lay 1.1-fold (0.05 log units) below the measured number; the range from low to high includes it.
By their numbers in this assay, from the lowest: compounds 2, 4, 1 and 3 (each within the scatter of the next, the first and the last beyond it).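

In this assay the larger 4-methoxyphenyl group fits this amide-type nitrogen with a 1.0-fold lower number from compound 1 to compound 4 (0.02 log units; within the scatter) as its step, so a third aryl replacement of allyl stays within the scatter. Methoxy on the aromatic carbon likewise gives a 1.2-fold lower number from compound 3 to compound 4 (0.07 log units; within the scatter) and a 1.9-fold higher number from compound 2 to compound 4 (0.28 log units; within the scatter) as its steps, so, unlike hydrogen in place of bromo, methoxy in place of bromo does not pass the scatter. No measurement here gives a reason for these numbers.

Still open, going by these compounds, is whether a longer chain in place of allyl, or an amine or a carboxylic acid on the phenyl ring, would move this read-out beyond the scatter.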